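Thiophen-2-yl for Furan-3-yl: What to Expect of Compound 4

The compounds below may be only part of what the source reports. "The series", "measured", "known", "first", "only" and "open" are said of these compounds alone.

Three compounds have been measured in an assay on membranes from HEK293 cells for displacement of a labelled ligand from adenosine receptor A2b (Homo sapiens), read by scintillation counting, with a stated time of 30 min, tested at 1 uM; on this read-out lower numbers stand for less inhibition and higher numbers for more inhibition at the one concentration tested (going by the name of the read-out):
Compound 1, `COC(=O)C1=C(C)NC(=S)NC1c1ccoc1`, gives 48%.
Compound 2, `COC(=O)C1=C(C)NC(=S)NC1c1cccs1`, gives 10%.
Compound 3, `COC(=O)C1=C(C)N(C)C(=O)NC1c1ccoc1`, gives 7%.

Compound 1 and compound 2 share a core and differ in one place: thiophen-2-yl in place of furan-3-yl on a saturated ring carbon. That change gave a number 38 percentage points lower from compound 1 to compound 2 (beyond the scatter). Compound 3 is built on a different core; how its core differs from that of compound 1 is not broken down here. In this assay the values of compound 2 and compound 3 lie within the usual scatter of each other, while compound 1 stands above both by more than the scatter.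

Compound 4, `COC(=O)C1=C(C)N(C)C(=O)NC1c1cccs1`, has not yet been measured in this assay. It stands to compound 3 as compound 2 stands to compound 1: thiophen-2-yl in place of furan-3-yl on a saturated ring carbon. The surroundings are not identical, since in this pair the saturated ring carbon is also three ring bonds from the ring atom that bears a methyl group (1 heavy atom), so it is the same kind of change rather than the same change. The earlier step was a large fall, but compound 3 already gives a low number, 7%, so a fall of like size is not expected here. Compound 4 is therefore expected to give about 5%, between 0% and 15%. That amounts to an expected step of a number 2 percentage points lower from compound 3 to compound 4 (within the scatter), small because compound 3 already gives 7%.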

Compound 4, a percentage reported as inhibition, at one concentration (the size of the read-out at that concentration, not a potency): 17%
Beside the measured number, compound 4's estimate is 12 percentage points below it; measured number above the stated range.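

In this assay, the same change on the core of compound 3 gave a number 10 percentage points higher from compound 3 to compound 4 (within the scatter), so here it leaves the number inside the usual scatter, whereas on the core of compound 1 it gave a large fall. The result of this change therefore did not carry from one core to the other in this series, and the two steps differ by more than their scatter allows: the same change on two cores in this assay, a number 38 percentage points lower (beyond the scatter) from compound 1 to compound 2 and a number 10 percentage points higher (within the scatter) from compound 3 to compound 4, 48 percentage points apart, beyond the scatter of two such steps. Going by these compounds alone, this does not show which feature of the two cores separates the steps, and with only one pair on each core it gives no rule for a further core; compound 3 also starts from a low number at the single concentration tested, which leaves little room to see a fall of the earlier size.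

The compounds shown carry only furan-3-yl or thiophen-2-yl on the saturated ring carbon, so it stays open how a phenyl ring or the other furan and thiophene attachments would behave on either core. All of them also keep the methoxycarbonyl group, which leaves open whether the same contrast between cores would hold with a carboxylic acid or a longer ester chain there.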